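Series notes: benzylsulfanyl in place of benzyloxy

The source may hold more compounds than are shown below. What is called first, only, known or untested is meant among the compounds shown, and "the series" means these compounds.

Measured compounds:
compound 1 `CCCCN(C)c1nc(C(C)(C)C)ccc1CNC(=O)C(C)c1ccc(NS(C)(=O)=O)c(F)c1` — 1.2 nM
compound 2 `CC(C(=O)NCc1ccc(C(C)(C)C)nc1OCc1ccccc1)c1ccc(NS(C)(=O)=O)c(F)c1` — 4.4 nM

In an assay on cells for antagonist activity at transient receptor potential cation channel subfamily V member 1 (Homo sapiens), read by FLIPR and calcium flux, with a stated time of 6 min (on this read-out higher numbers stand for weaker inhibition and lower numbers for stronger inhibition), compound 1 gives 1.2 nM and compound 2 gives 4.4 nM. Among the compounds with values here, compound 2 therefore stands at the higher of the two numbers so far, with compound 1 as its only neighbour; the step of a 3.7-fold higher number from compound 1 to compound 2 (0.56 log units; beyond the scatter) lies beyond the scatter and is the only step measured.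

Compound 3 `CC(C(=O)NCc1ccc(C(C)(C)C)nc1SCc1ccccc1)c1ccc(NS(C)(=O)=O)c(F)c1` is not yet measured. It differs from compound 2 in one place: benzylsulfanyl in place of benzyloxy on an aromatic carbon. Within the data shown here, no measured step bears directly on this exchange; the single step from compound 1 to compound 2 swapped a butyl(methyl)amino for a benzyloxy, which is a different change, and it was only modest in size. With the benzyl part kept and only the linking atom exchanged, compound 3 is expected to stay close to compound 2, and the expected step of a 1.1-fold higher number from compound 2 to compound 3 (0.06 log units; within the scatter) is put within or near the scatter. On this basis the estimate for compound 3 in this assay is 5 nM, with a range from 1.5 nM to 16 nM.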

Compound 3, inhibition constant: 4 nM
Compound 3: the middle estimate sits 1.3-fold (0.10 log units) above what was measured, and the stated range covers the measured number.
By their numbers in this assay, from the lowest: compound 1; then compounds 3 and 2 (each within the scatter of the next).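

In this assay, the atom linking the benzyl group to this aromatic carbon next to the ring nitrogen can be oxygen or sulfur with the two numbers staying within the scatter of each other: a 1.1-fold lower number from compound 2 to compound 3 (0.04 log units; within the scatter). The butyl(methyl)amino group keeps the lowest number of the three, as its exchange for benzylsulfanyl gives a 3.3-fold higher number from compound 1 to compound 3 (0.52 log units; beyond the scatter), a modest step beyond the scatter and in the same direction as the exchange for benzyloxy, a 3.7-fold higher number from compound 1 to compound 2 (0.56 log units; beyond the scatter). No measurement at hand explains why the two benzyl-linked compounds fall within the scatter of each other or why the butyl(methyl)amino group gives the lowest number.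

Open, going by these compounds, is whether the benzyl part matters at this carbon or only the linking atom, a question that a butylsulfanyl group or a benzylamino group, with nitrogen as the linking atom, would help to separate. Also open, on these data alone, is whether the gap to the butyl(methyl)amino group follows the nitrogen link or the butyl chain, which a benzyl(methyl)amino group on the same carbon would test.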